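Changing the pyridine substituents on a fused bicyclic core

The compounds below may be only part of what the source reports. "The series", "measured", "known", "first", "only" and "open" are said of these compounds alone.

Of the compounds shown here, two have been tested in an assay on isolated protein for binding affinity to corticotropin-releasing factor receptor 1 (Homo sapiens); on this read-out higher numbers stand for weaker inhibition and lower numbers for stronger inhibition. Compound 1 `CCCN(CC1CC1)c1cc(C)nc2c(-c3ncc(Cl)cc3Cl)c(C)nn12` gives 3.9 nM. Compound 2 `CCCN(CCC)c1cc(C)nc2c(-c3ncc(NC)cc3C)c(C)nn12` gives 40 nM, the higher of the two numbers; the nearest neighbour is compound 1, whose number is lower by a gap that exceeds the usual scatter, so compound 2 is the weaker binder of the pair.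

Compound 3 `CCCN(CCC)c1cc(C)nc2c(-c3ncc(C)cc3O)c(C)nn12` has not yet been measured. It differs from compound 2 in a single place, on an aromatic carbon of a five-membered aromatic ring with 2 nitrogen, part of a fused or bridged system of two rings: 3-hydroxy-5-methylpyridin-2-yl in place of 3-methyl-5-(methylamino)pyridin-2-yl on an aromatic carbon.

Going by the values given here, no measured pair shows what such a swap does here, so the expectation rests on compound 2 alone. The step of a 1.5-fold higher number from compound 2 to compound 3 (0.18 log units; within the scatter) is expected to be small and not clearly beyond the scatter. Compound 3 is therefore expected to give about 60 nM, within a range of 15 nM to 250 nM.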

Compound 3, inhibition constant: > 10000 nM
Compound 3: only a limit was reported (the forecaster's own chance of this, stated with the estimate: 5%); middle value at least 160-fold (2.22 log units) from the limit.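

In this assay compound 3 gives > 10000 nM, which is a limit of the assay and not a number. On this aromatic carbon, 3-hydroxy-5-methylpyridin-2-yl in place of 3-methyl-5-(methylamino)pyridin-2-yl is no minor edit: the result is an at least 250-fold higher number from compound 2 to compound 3 (2.39 log units; beyond the scatter), even though both groups are six-membered aromatic rings with the same counts of hydrogen-bond donors and acceptors and no net charge. Matching those counts therefore does not keep binding at this position, and the true size of the step stays unknown, as it rests on a limit: the limit of > 10000 nM in this assay, at which 1 of the 3 values shown sits.

The swap changes more than one substituent on the pyridine at once, so the compounds shown do not tell which change matters. Going by these compounds, whether a methoxy group in place of the hydroxy group, or a primary amine in place of the methylamino group, would keep binding remains open.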